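Chloro added to the ethoxy compound 2

The source may hold more compounds than are shown below. What is called first, only, known or untested is meant among the compounds shown, and "the series" means these compounds.

In a functional assay on HeLa cells (Homo sapiens) for cytotoxicity, read by XTT assay, with a stated time of 24 h (a lower number here means a stronger inhibitor, a higher number a weaker inhibitor), compound 1 (`CC(=O)Oc1cc(C)c(Cl)c2c1C(=O)C=CC2=O`) gives 26200 nM and compound 2 (`CCOc1cc(C)cc2c1C(=O)C=CC2=O`) gives 29700 nM so compound 2 stands level with compound 1, within the scatter. Compound 3 (`CCOc1cc(C)c(Cl)c2c1C(=O)C=CC2=O`) differs from compound 2 in one place (chloro in place of hydrogen on an aromatic carbon): chloro in place of hydrogen on an aromatic carbon, para to an ethoxy group. For the measured compounds named here, no measured pair shows this change alone. Compound 1 does carry chloro and gives 26200 nM so only a small move towards a lower number is expected in this assay and it may stay within the scatter. The expected step is a 1.5-fold lower number from compound 2 to compound 3 (0.17 log units; within the scatter) and no more. Compound 3 is estimated at 20000 nM (expected range 8000 nM to 45000 nM).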

Compound 3, half-maximal inhibitory concentration: 19000 nM
Compound 3: the middle estimate sits 1.1-fold (0.02 log units) above what was measured, and the stated range covers the measured number.
By their numbers in this assay, from the lowest: compounds 3, 1 and 2 (each within the scatter of the next).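

In this assay, for the compounds shown here, chloro in place of hydrogen on an aromatic carbon, para to an ethoxy group, gives a 1.6-fold lower number from compound 2 to compound 3 (0.19 log units; within the scatter), the first direct reading of this change at this position, and it leaves the two compounds level. With chloro present in both, ethyl in place of acetyl on the oxygen gives a 1.4-fold lower number from compound 1 to compound 3 (0.14 log units; within the scatter), so that change also leaves the compounds level. Nothing measured here bears on a cause for either step. Going by these compounds, whether bromo or an amine at this position would give a step beyond the scatter remains open. On these data alone, a longer chain on the oxygen is equally open.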